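This account rests on a few compounds, and the source may have more. Where it says the series, first, only, none or still open, it means among the compounds named here.

Of the compounds shown here, three sharing one core have been tested in an ADME assay on HaCaT cells (Homo sapiens) for antiproliferative activity, read by MTT assay, with a stated time of 48 h; on this read-out higher numbers stand for weaker inhibition and lower numbers for stronger inhibition. Compound 1, `COc1cc(N/C=C\C(=O)c2cn(-c3ccccc3)nc2-c2ccccc2)cc(OC)c1OC`, gives 36200 nM. Compound 2, `O=C(/C=C\Nc1ccc(Cl)cc1)c1cn(-c2ccccc2)nc1-c1ccc(Cl)cc1`, gives 23400 nM in this assay. Compound 3, `COc1cc(-c2nn(-c3ccccc3)cc2C(=O)/C=C\Nc2ccc(F)cc2)cc(OC)c1OC`, gives 25700 nM in this assay. On the numbers shown, compound 3 stands close to both of its companions: its gap to compound 2 and its gap to compound 1 each fall inside the usual scatter of repeated measurements, so the three compounds cannot be told apart on this read-out.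

Compound 4, `COc1ccc(N/C=C\C(=O)c2cn(-c3ccccc3)nc2-c2cc(OC)c(OC)c(OC)c2)cc1`, differs from compound 3 in one place: methoxy in place of fluoro on an aromatic carbon. Among the measured compounds shown here, no pair of measured compounds shows this exchange, so there is no measured step to lean on. The three measured values lie close together although their substituents differ, and the data give no ground for a shift of any size in either direction. The expected step is therefore a 1.1-fold higher number from compound 3 to compound 4 (0.02 log units; within the scatter), which is none beyond the scatter. Compound 4 is estimated to give 27000 nM in this assay, with a likely range from 13000 nM to 56000 nM.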

Compound 4, half-maximal inhibitory concentration: > 50000 nM
Compound 4 ended at the assay's limit; the forecaster's own chance of this, stated with the estimate: 10%; middle value at least 1.8-fold (0.26 log units) away from the limit.
By their numbers in this assay, from the lowest: compounds 2, 3 and 1 (each within the scatter of the next). At a limit, above all of these: compound 4.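

Among the compounds shown here, this is the first pair in the set that differs in one place, so it is the first direct look at what this position on the ring does. In this assay compound 4 gives > 50000 nM, which is a limit of the assay and not a number. Going from 4-fluorophenyl to 4-methoxyphenyl, the exchange reads as an at least 1.9-fold higher number from compound 3 to compound 4 (0.28 log units; that floor lies within the scatter), so the direction is upward but the guaranteed part of the step does not clear the usual scatter on its own. As far as these compounds go, the step can be given only as a floor, and its true size stays unknown, because one end of it sits at a limit: the limit of > 50000 nM in this assay, at which 1 of the 4 values shown sits.

From the compounds shown here alone, how far compound 4 really lies from compound 3 remains open, and a single exchange cannot show whether the methoxy group or simply a change from fluoro drives the result. Also open, going by these compounds, is how other groups at this same place would behave, such as an amine or a carboxylic acid, and whether the same exchange would read the same way with different groups elsewhere on the shared core.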